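Estimating Cytotoxicity of a Methylsulfonyl Ester Analogue

The compounds below may be only part of what the source reports. "The series", "measured", "known", "first", "only" and "open" are said of these compounds alone.

Of the compounds shown here, three sharing one core have been tested in an ADME assay on Vero cells (Chlorocebus sabaeus) for cytotoxicity, read by MTT assay, with a stated time of 48 h; a lower number here means a stronger inhibitor, a higher number a weaker inhibitor. Compound 1 `CS(=O)(=O)NC1CCC(CN2CCN(c3cc(=O)c4cc(C(F)(F)F)cc([N+](=O)[O-])c4s3)CC2)CC1` carries a methanesulfonamido group on a saturated ring carbon, and in this assay compound 1 gives 48.5 ug/mL. Compound 2 `O=c1cc(N2CCN(CC3CCC(OS(=O)(=O)c4ccccc4)CC3)CC2)sc2c([N+](=O)[O-])cc(C(F)(F)F)cc12` bears (phenylsulfonyl)oxy in place of methanesulfonamido on a saturated ring carbon; in this assay compound 2 reaches only the limit of the assay, > 64 ug/mL. Compound 3 `COc1ccc(C(=O)OC2CCC(CN3CCN(c4cc(=O)c5cc(C(F)(F)F)cc([N+](=O)[O-])c5s4)CC3)CC2)cc1` carries ((4-methoxyphenyl)carbonyl)oxy in place of methanesulfonamido on a saturated ring carbon; in this assay compound 3 likewise stands at a limit rather than a number, > 64 ug/mL, in line with the limit of > 64 ug/mL in this assay, at which 2 of the 3 values shown sit.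

Compound 4 `CS(=O)(=O)OC1CCC(CN2CCN(c3cc(=O)c4cc(C(F)(F)F)cc([N+](=O)[O-])c4s3)CC2)CC1` differs from compound 3 as follows: methylsulfonyl in place of (4-methoxyphenyl)carbonyl on an oxygen on a saturated carbon. Of the measured steps, a step that the two limits leave unreadable from compound 2 to compound 3 concerns the same oxygen on a saturated carbon but cannot be sized. The steps of an at least 1.3-fold higher number from compound 1 to compound 2 (0.12 log units; that floor lies within the scatter) and an at least 1.3-fold higher number from compound 1 to compound 3 (0.12 log units; that floor lies within the scatter) are floors lying within the scatter. Compound 4 combines the methylsulfonyl seen in compound 1 with the oxygen on a saturated carbon seen in compound 2, and none of these steps points beyond the scatter. The step is estimated at an at least 1.1-fold lower number from compound 3 to compound 4 (0.06 log units; that floor lies within the scatter). Compound 4 is therefore expected near 55 ug/mL, between 30 ug/mL and 100 ug/mL, with a fair chance that only a limit is reported.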

Compound 4, half-maximal inhibitory concentration: > 64 ug/mL
Compound 4 was reported as a limit; the forecaster's own chance of this, stated with the estimate: 50%; middle value at least 1.1-fold (0.06 log units) from the limit.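

In this assay compound 4 also stands at a limit of the assay rather than a number, > 64 ug/mL. Among these compounds, the only step that can be sized is an at least 1.3-fold higher number from compound 1 to compound 4 (0.12 log units; that floor lies within the scatter), so even this direct exchange of the two methylsulfonyl-bearing groups does not separate them beyond the scatter. The steps among compounds 2, 3 and 4 cannot be read, but the result adds a group with no ring to the two aromatic groups already seen on the oxygen on a saturated carbon, and all three compounds with such an oxygen share one reading: the limit of > 64 ug/mL in this assay, at which 3 of the 4 values shown sit.

From the compounds shown here alone, how far compounds 2, 3 and 4 lie past that limit remains open, and with it any order among them. Also open, going by these compounds, is whether a free hydroxyl on the saturated ring carbon, an acetyl group on the same oxygen or an amine in place of that oxygen would give a number within the range of this assay.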